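From an Aminoethyl to an Aminocyclohexyl Side Chain

The compounds below may be only part of what the source reports. "The series", "measured", "known", "first", "only" and "open" are said of these compounds alone.

Of the compounds shown here, three sharing one core have been measured in a functional assay on HCT-116 cells (Homo sapiens) for cytotoxicity, read by fluorescence, with a stated time of 72 h; on this read-out higher numbers stand for weaker inhibition and lower numbers for stronger inhibition. Compound 1 `CC(C)c1n[nH]c2c(NCc3ccc(-c4ccccn4)cc3)nc(NCCO)nc12` gives 27 nM, compound 2 `CC(C)c1n[nH]c2c(NCc3ccc(-c4ccccn4)cc3)nc(N3CCCCC3CCO)nc12` gives 142 nM, and compound 3 `CC(C)c1n[nH]c2c(NCc3ccc(-c4ccccn4)cc3)nc(NCCN)nc12` gives 227 nM. Compound 3 therefore sits close to compound 2, as a 1.6-fold higher number from compound 2 to compound 3 (0.20 log units; within the scatter) lies within the scatter, and apart from compound 1, as an 8.4-fold higher number from compound 1 to compound 3 (0.92 log units; beyond the scatter) lies beyond it.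

Compound 4 `CC(C)c1n[nH]c2c(NCc3ccc(-c4ccccn4)cc3)nc(N[C@@H]3CCCC[C@H]3N)nc12` carries 2-aminocyclohexyl in place of 2-aminoethyl on a nitrogen on an aromatic ring. Among the compounds with values here, no measured step makes this exact change. The closest guide is compound 2, where a ring entered the hydroxy-bearing side chain in a 5.3-fold higher number from compound 1 to compound 2 (0.72 log units; beyond the scatter), a modest step towards weaker inhibition. That step, however, did not start from the amino-bearing chain of compound 3, so it transfers only loosely. No clear step is therefore expected, and the wide range reflects this uncertainty. The expected change, a 1.3-fold lower number from compound 3 to compound 4 (0.13 log units; within the scatter), is an estimate with no firm direction. Compound 4 is estimated at 170 nM, with an expected range from 50 nM to 600 nM.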

Compound 4, half-maximal inhibitory concentration: 427 nM
Estimate against measurement, compound 4: 2.5-fold (0.40 log units) below, and the stated range covers the measured number.
By their numbers in this assay, from the lowest: compound 1; then compounds 2, 3 and 4 (each within the scatter of the next, the first and the last beyond it).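

In this assay, 2-aminocyclohexyl in place of 2-aminoethyl on this nitrogen gives a 1.9-fold higher number from compound 3 to compound 4 (0.27 log units; within the scatter) and so stays within the scatter: drawing the amino-bearing chain into a six-membered carbon ring brings no clear change here. Compound 4 still stands apart from the other two side chains, with a 3.0-fold higher number from compound 2 to compound 4 (0.48 log units; beyond the scatter) as a modest step and a 16-fold higher number from compound 1 to compound 4 (1.20 log units; beyond the scatter) as a large one, the widest gap in the set so far. The data offer no measured evidence that explains these differences.

The compounds shown leave open whether 2-hydroxycyclohexyl on the same nitrogen would read closer to compound 1 or to compound 4, and whether a longer chain such as 3-aminopropyl would differ from 2-aminoethyl. They also leave open how the opposite stereoisomers of 2-aminocyclohexyl would read.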